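Methoxy on the Benzamide: Expected Tolerance in TZM Cells

A few compounds are considered here, and "the series" means these few. Any claim that something is new, unique, unknown or untested is made for them only; others in the source may bear on it.

Compound 1 `CC(=O)Oc1ccc(/C=C/S(=O)(=O)CCc2ccc(NC(=O)c3ccccc3)cc2)cc1OC(C)=O` and compound 2 `COc1ccc(C(=O)Nc2ccc(CCS(=O)(=O)/C=C/c3ccc(OC(C)=O)c(OC(C)=O)c3)cc2)cc1` share one core, while compound 3 `O=C(Nc1ccc(CCS(=O)(=O)/C=C/c2ccc(O)c(O)c2)cc1)c1ccccc1` and the as yet unmeasured compound 4 `COc1ccc(C(=O)Nc2ccc(CCS(=O)(=O)/C=C/c3ccc(O)c(O)c3)cc2)cc1` share another; the difference between the two cores is not broken down here. In an ADME assay on TZM cells (Homo sapiens) for cytotoxicity, read by CCK-8 assay, with a stated time of 2 days (a lower number here means that less compound is tolerated, a higher number that more compound is tolerated), compound 1 gives 108000 nM and compound 2 gives 858000 nM. The change that separates them, (methoxy in place of hydrogen on an aromatic carbon), made a 7.9-fold higher number from compound 1 to compound 2 (0.90 log units; beyond the scatter). Compound 3 in this assay gives 238000 nM, which places it between compound 1 and compound 2. Among the measured compounds shown here, compound 4 carries the same change relative to compound 3, namely (methoxy in place of hydrogen on an aromatic carbon), at the same place on the ring, so the earlier step is the only guide to what it may do. Because that step was a 7.9-fold higher number from compound 1 to compound 2 (0.90 log units; beyond the scatter), compound 4 is expected to move in the same direction, and the estimated step is a 3.8-fold higher number from compound 3 to compound 4 (0.58 log units; beyond the scatter), set somewhat smaller than the earlier one since a single precedent on a different core is a thin basis. For compound 4 in this assay the estimate is 900000 nM, with a range from 300000 nM to 2500000 nM.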

Compound 4, half-maximal cytotoxic concentration: > 1000000 nM
Compound 4 was reported as a limit (the forecaster's own chance of this, stated with the estimate: 20%); middle value at least 1.1-fold (0.04 log units) from the limit.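

In this assay, methoxy in place of hydrogen on an aromatic carbon, para to a large group, moved the number the same way on both cores, giving an at least 4.2-fold higher number from compound 3 to compound 4 (0.62 log units; beyond the scatter). Compound 4 stands at > 1000000 nM, which is a limit of the assay and not a number. The direction of the change therefore carried from the core of compound 1 to the core of compound 3 in this one pair of steps, but two steps do not establish a rule for the series, and whether the size of the change carried over remains unsettled: the same change on two cores in this assay, a 7.9-fold higher number (0.90 log units; beyond the scatter) from compound 1 to compound 2 and an at least 4.2-fold higher number (0.62 log units; beyond the scatter) from compound 3 to compound 4; the limit leaves it open whether they differ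

The compounds shown follow only methoxy, at one place on the ring and on two cores, so they leave open whether the same rise would appear on a third core or with methoxy elsewhere on that ring. They also leave open how an amine, a carboxylic acid or a longer alkoxy chain in place of the methoxy would behave in this assay.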